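Swapping a Hexyl Chain for 4-Chlorophenyl on the Amine

The source may report more compounds than this note shows. Statements on the series, on what has been measured and on what is new or still open speak of the compounds shown alone.

Of the compounds shown here, three sharing one core have been tested in a functional assay on MGC-803 cells (Homo sapiens) for cytotoxicity, read by MTT assay, with a stated time of 72 h; on this read-out lower numbers stand for stronger inhibition and higher numbers for weaker inhibition. Compound 1 `CCCCCCNc1nc(SCc2ccc(C(F)(F)F)cc2)nc2ccccc12` gives 13100 nM, the lowest of the two numbers reported. Compound 2 `FC(F)(F)c1ccc(CSc2nc(N3CCCCC3)c3ccccc3n2)cc1` sits close by at 18600 nM, and the comparison shows a 1.4-fold higher number from compound 1 to compound 2 (0.15 log units; within the scatter). Compound 3 `FC(F)(F)c1ccc(CSc2nc(Nc3ccccc3Cl)c3ccccc3n2)cc1` reaches only the limit of this assay, > 50000 nM. The unmeasured compound 4 `FC(F)(F)c1ccc(CSc2nc(Nc3ccc(Cl)cc3)c3ccccc3n2)cc1` differs from compound 1 in one place: 4-chlorophenyl in place of hexyl on a nitrogen on an aromatic ring. The closest measured precedent is the other chlorophenylamino compound, compound 3: there was an at least 3.8-fold higher number from compound 1 to compound 3 (0.58 log units; beyond the scatter), and an at least 2.6-fold higher number from compound 2 to compound 3 (0.42 log units; beyond the scatter); both steps are open-ended because of the limit of > 50000 nM in this assay, at which 1 of the 3 values shown sits. Since compound 4 carries a chlorophenyl group on the same nitrogen as compound 3, a loss of similar size is expected, and the estimated step is a 3.1-fold higher number from compound 1 to compound 4 (0.48 log units; beyond the scatter), quite possibly ending at the limit again. Compound 4 is therefore expected to give about 40000 nM in this assay, with a range from 15000 nM to 120000 nM.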

Compound 4, half-maximal inhibitory concentration: 16800 nM
The estimate for compound 4 lay 2.4-fold (0.38 log units) above the measured number; the range from low to high includes it.
By their numbers in this assay, from the lowest: compounds 1, 4 and 2 (each within the scatter of the next). At a limit, above all of these: compound 3.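

An aromatic ring on this nitrogen carries no visible cost in this assay: there is a 1.3-fold higher number from compound 1 to compound 4 (0.11 log units; within the scatter), and also a 1.1-fold lower number from compound 2 to compound 4 (0.04 log units; within the scatter), so 4-chlorophenyl, hexyl and piperidin-1-yl cannot be told apart here. The loss seen with compound 3 therefore does not extend to every chlorophenyl group, since 4-chlorophenyl in place of 2-chlorophenyl gives an at least 2.9-fold lower number from compound 3 to compound 4 (0.47 log units; beyond the scatter). That step has no fixed size because compound 3 stands at a limit: the limit of > 50000 nM in this assay, at which 1 of the 4 values shown sits.

Still open, from the compounds shown here alone, is how a plain phenyl group or a benzyl group would behave on this nitrogen, and whether either would follow compound 4 or compound 3. Going by these compounds, it is also open whether a shorter chain such as butyl, or a morpholine ring in place of the piperidine, would move the number beyond the scatter.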